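From Oxetan-3-yl to Pyrimidin-2-yl: Cytotoxicity Outlook

The source may hold more compounds than are shown below. What is called first, only, known or untested is meant among the compounds shown, and "the series" means these compounds.

Compound 3 `CN1C(=S)[C@@H](NC(=O)c2nc(Cc3ccccc3)n(C3COC3)n2)COc2ccccc21` carries an oxetan-3-yl group on an aromatic nitrogen of the shared core. In a toxicity assay on HT-29 cells (Homo sapiens) for cytotoxicity (a lower number here means that less compound is tolerated, a higher number that more compound is tolerated), compound 3 gives only a limit of the assay, > 100000 nM. Its two neighbours tell the same story. Compound 1 `CC(C)n1nc(C(=O)N[C@H]2COc3ccccc3N(C)C2=S)nc1Cc1ccccc1`, with isopropyl in that place, also reaches only the limit, > 100000 nM in this assay. Compound 2 `CN1C(=S)[C@@H](NC(=O)c2nc(Cc3ccccc3)n(C3CCCCC3)n2)COc2ccccc21`, with cyclohexyl there, likewise stops at the limit, > 100000 nM. Because all three sit at the limit of > 100000 nM in this assay, at which 3 of the 3 values shown sit, the steps a step that the two limits leave unreadable from compound 1 to compound 3 and a step that the two limits leave unreadable from compound 2 to compound 3 cannot be sized, and nothing here separates the three groups from one another.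

Compound 4 `CN1C(=S)[C@@H](NC(=O)c2nc(Cc3ccccc3)n(-c3ncccn3)n2)COc2ccccc21` differs from compound 3 by pyrimidin-2-yl in place of oxetan-3-yl on an aromatic nitrogen. Within the data shown here, no measured step bears on pyrimidin-2-yl itself; the three values show only that none of the groups tried so far brought the half-maximal cytotoxic concentration under the limit. The step of a number no higher from compound 3 to compound 4 (the limit leaves the size open) is therefore expected to be none beyond the scatter. Compound 4 is estimated at 100000 nM, between 40000 nM and 250000 nM, most likely reported once more as a limit.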

Compound 4, half-maximal cytotoxic concentration: > 100000 nM
Compound 4: a limit, no number (the forecaster's own chance of this, stated with the estimate: 85%); the middle value sits exactly at the limit.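

In this assay compound 4 gives only a limit, > 100000 nM. Its steps from compound 1, compound 2 and compound 3 cannot be read, since all four stop at the same limit: the limit of > 100000 nM in this assay, at which 4 of the 4 values shown sit. Going by these compounds, how far each compound lies past that limit, and whether any group on this aromatic nitrogen would fall under it, stays open.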